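The source may hold more compounds than are shown below. What is called first, only, known or untested is meant among the compounds shown, and "the series" means these compounds.

Working notes on the series. The shared core is carried in compound 1 `Cc1c(C)c2c(c(C)c1O)CCC(C)(CNCCCCn1ccc(=O)c(O)c1C)O2`, compound 2 `Cc1c(C)c2c(c(C)c1OC(=O)CCN)CC(CCn1ccc(=O)c(O)c1C)O2` and compound 3 `Cc1c(C)c2c(c(C)c1OC(=O)c1ccc(N)cc1)CC(CCn1ccc(=O)c(O)c1C)O2`; compound 4 `Cc1c(C)c2c(c(C)c1OC(=O)C(N)C(C)C)CC(CCn1ccc(=O)c(O)c1C)O2` is not yet measured. Among the compounds with values here, in an ADME assay for solubility (on this read-out lower numbers stand for lower solubility and higher numbers for higher solubility), compound 2 gives 10000 ug/mL, the only number among the three values shown. For compound 1 the read-out is a limit, < 100 ug/mL. For compound 3 the read-out is likewise a limit, < 100 ug/mL. Two of the three values thus sit at the limit of < 100 ug/mL in this assay, at which 2 of the 3 values shown sit, and compound 2 alone stands above it. Within the data shown here, the single computable step, an at least 100-fold lower number from compound 2 to compound 3 (2.00 log units; beyond the scatter), is large. Compound 4 differs from compound 2 by 1-amino-2-methylpropyl in place of 2-aminoethyl on a carbonyl carbon. Among the measured compounds shown here, the measured step to compound 3 brings in 4-aminophenyl, whereas the change to compound 4 keeps an open-chain aminoalkyl group on the carbonyl carbon; no measured step bears directly on this change. The step expected in this assay is a 2.0-fold lower number from compound 2 to compound 4 (0.30 log units; within the scatter), either within the scatter or a modest fall. Compound 4 is accordingly estimated at 5000 ug/mL, with a range from 1500 ug/mL to 10000 ug/mL.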

Compound 4, solubility: > 20000 ug/mL
Compound 4: a limit, no number (the forecaster's own chance of this, stated with the estimate: 15%); middle value at least 4.0-fold (0.60 log units) from the limit.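

In this assay compound 4 gives a limit and not a number: the limit of > 20000 ug/mL in this assay, at which 1 of the 4 values shown sits.

On a carbonyl carbon, 1-amino-2-methylpropyl in place of 2-aminoethyl gives an at least 2.0-fold higher number from compound 2 to compound 4 (0.30 log units; that floor lies within the scatter), so the longer open-chain group shows no loss on this read-out, although the floor of that step does not separate the two compounds. Set against 4-aminophenyl, the same group gives an at least 200-fold higher number from compound 3 to compound 4 (2.30 log units; beyond the scatter), so the large drop seen with 4-aminophenyl is not shared by this second open-chain aminoalkyl group.

From the compounds shown here alone, how far compound 4 lies past its limit cannot be read, and the true size of the step from compound 2 stays open. Also open, going by these compounds, is how a carboxylic acid or a longer aminoalkyl chain would read on the same carbonyl carbon.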